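This account rests on a few compounds, and the source may have more. Where it says the series, first, only, none or still open, it means among the compounds named here.

Compound 2 `COc1ccc(/C=C/c2cc(OC)cc(OC)c2/C=C/C(=O)c2cc3cccc(C)c3oc2=O)cc1` stands with the lowest number of the two compounds measured in an assay on isolated protein for inhibition of Amine oxidase [flavin-containing] B (Homo sapiens), read by fluorescence, with a stated time of 15 min; on this read-out lower numbers stand for stronger inhibition and higher numbers for weaker inhibition; in this assay compound 2 gives 20000 nM, and its nearest neighbour, compound 1 `COc1ccc(/C=C/c2cc(OC)cc(OC)c2/C=C/C(=O)c2cc3ccc(Br)cc3oc2=O)cc1`, gives 55300 nM. The move from compound 2 to compound 3 `COc1ccc(/C=C/c2cc(OC)cc(OC)c2/C=C/C(=O)c2cc3cc(F)ccc3oc2=O)cc1` is a group of 12 heavy atoms (9 carbon, 2 oxygen, 1 fluorine; one six-membered aromatic ring of carbon only, one six-membered aromatic ring with 1 hetero atom) in place of a group of 12 heavy atoms (10 carbon, 2 oxygen; one six-membered aromatic ring of carbon only, one six-membered aromatic ring with 1 hetero atom), on a carbonyl carbon. For the measured compounds named here, the only measured step, a 2.8-fold lower number from compound 1 to compound 2 (0.44 log units; beyond the scatter), also exchanged one of these groups for another on the same carbonyl carbon, there from a bromine-bearing group to one without a halogen, and the number fell modestly. Compound 3 goes in the opposite sense, from the group without a halogen to a fluorine-bearing one, so a modest rise in the number is expected, a 1.8-fold higher number from compound 2 to compound 3 (0.24 log units; within the scatter), though a single step is thin ground. Compound 3 is therefore estimated at 35000 nM in this assay, with a range from 15000 nM to 80000 nM.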

Compound 3, half-maximal inhibitory concentration: 10200 nM
Compound 3: middle estimate off by 3.4-fold (0.54 log units), on the high side; measured number below the stated range.
By their numbers in this assay, from the lowest: compounds 3 and 2 (each within the scatter of the next); then compound 1.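

The step to the fluorine-bearing group (a 2.0-fold lower number from compound 2 to compound 3 (0.29 log units; within the scatter)) lies within the scatter, so in this assay this group cannot be told apart from the group without a halogen, and a halogen on the group at this carbonyl carbon does not of itself go with a higher number. The two halogen-bearing groups do part (a 5.4-fold lower number from compound 1 to compound 3 (0.73 log units; beyond the scatter)), which among these three compounds leaves the bromine-bearing group of compound 1 alone apart from the others, rather than halogens as a class. Nothing available here explains why these groups read as they do.

The compounds shown leave open how a chlorine-bearing group, or one carrying an amine or a carboxylic acid, would read on this carbonyl carbon. From the compounds shown here alone, whether these changes would read alike on a core without the methoxy groups also remains open.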